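Hydroxy for Chloro on the Aryl Ring of Compound 3

The compounds below may be only part of what the source reports. "The series", "measured", "known", "first", "only" and "open" are said of these compounds alone.

Compound 3 `Clc1cccc(-c2nc(N3CCCCC3)c3nc[nH]c3n2)c1` gives 50.1 nM in an assay on cells for displacement of a labelled ligand from adenosine receptor A1 (Homo sapiens), read by scintillation counting and radioligand binding, with a stated time of 60 min (a higher number here means a weaker inhibitor, a lower number a stronger inhibitor), the lowest of the three numbers shown. Compound 1 `CN1CCN(c2nc(-c3ccc(Cl)cc3)nc3[nH]cnc23)CC1` gives 398 nM and compound 2 `CN1CCN(c2nc(-c3ccc(Cl)c(Cl)c3)nc3[nH]cnc23)CC1` gives 631 nM. For the measured compounds named here, the one measured step, a 1.6-fold higher number from compound 1 to compound 2 (0.20 log units; within the scatter), concerns chloro entering on an aromatic carbon of the core of compound 1 and speaks only indirectly to the change at hand. Compound 4 `Oc1cccc(-c2nc(N3CCCCC3)c3nc[nH]c3n2)c1` differs from compound 3 by hydroxy in place of chloro on an aromatic carbon. Going by the values given here, no measured pair exchanges chloro for hydroxy, so the expectation rests on that single small step alone. Compound 4 is expected to show a moderately higher number, a step of a 3.0-fold higher number from compound 3 to compound 4 (0.48 log units; beyond the scatter). Compound 4 is therefore estimated at 150 nM, within a range of 40 nM to 600 nM.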

Compound 4, inhibition constant: 10 nM
Compound 4: middle estimate off by 15-fold (1.18 log units), on the high side, outside the stated range (below it).
By their numbers in this assay, from the lowest: compound 4; then compound 3; then compounds 1 and 2 (each within the scatter of the next).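

Hydroxy in place of chloro on this aromatic carbon, meta to a large group, brought a 5.0-fold lower number from compound 3 to compound 4 (0.70 log units; beyond the scatter) in this assay. The earlier compounds shown here showed only chloro entering on the core of compound 1, with a change within the scatter, and gave no sign that this position could gain from a group bearing a hydrogen-bond donor. Nothing measured here accounts for the gain. The compounds shown leave open whether methoxy, an amine or a carboxylic acid on this carbon would match hydroxy. Going by these compounds, whether 3-hydroxyphenyl would bring a similar step on the core of compound 1 also remains open.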